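Five-membered heteroaryl swaps on a shared core

A few compounds are considered here, and "the series" means these few. Any claim that something is new, unique, unknown or untested is made for them only; others in the source may bear on it.

Compound 1 `CCC(C)(C)Cc1c[nH]c(CCc2ccc(-n3ncnn3)cc2)n1`; in a functional assay on HEK293 cells for agonist activity at Bombesin receptor subtype-3 (Mus musculus), read by luminescence and calcium flux, with a stated time of 10 min (a lower number here means that less compound is needed, a higher number that more compound is needed for the effect), compound 1 gives 99 nM.
Compound 2 `CCC(C)(C)Cc1c[nH]c(CCc2ccc(-c3cccc(C#N)n3)cc2)n1`; compound 2 gives 115 nM.
Compound 3 `CCC(C)(C)Cc1c[nH]c(CCc2ccc(-n3cncn3)cc2)n1`; compound 3 gives 121 nM.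

Compound 3 holds the largest of the three numbers, yet the steps of a 1.2-fold higher number from compound 1 to compound 3 (0.09 log units; within the scatter) and a 1.1-fold higher number from compound 2 to compound 3 (0.02 log units; within the scatter) both sit within the scatter, as does a 1.2-fold higher number from compound 1 to compound 2 (0.07 log units; within the scatter), so the three compounds are not separated in this assay. Compound 4 `CCC(C)(C)Cc1c[nH]c(CCc2ccc(-c3ccns3)cc2)n1` is not yet measured; it differs from compound 3 by 1,2-thiazol-5-yl in place of 1H-1,2,4-triazol-1-yl on an aromatic carbon. All three measured steps exchange the group at this same place and none moves beyond the scatter, so the step from compound 3 to compound 4 is expected to be of the same kind: a 1.0-fold lower number from compound 3 to compound 4 (0.00 log units; within the scatter). Compound 4 is estimated at 120 nM, with a range from 50 nM to 300 nM.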

Compound 4, half-maximal effective concentration: 103 nM
Compound 4: the middle estimate sits 1.2-fold (0.07 log units) above what was measured; the range from low to high includes it.
By their numbers in this assay, from the lowest: compounds 1, 4, 2 and 3 (each within the scatter of the next).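

In this assay a five-membered aromatic ring holding sulfur takes this place, para to a large group, without leaving the scatter: a 1.2-fold lower number from compound 3 to compound 4 (0.07 log units; within the scatter), a 1.1-fold lower number from compound 2 to compound 4 (0.05 log units; within the scatter), and a 1.0-fold higher number from compound 1 to compound 4 (0.02 log units; within the scatter). Sulfur in the ring and one hetero atom fewer than in 1H-1,2,4-triazol-1-yl thus leave these four compounds unseparated. No measurement bears on why the numbers stay together.

As far as these compounds go, whether a carboxylic acid, a primary amine or a plain hydrogen at this place would separate from these four remains open.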